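Solubility Expectation for a Trifluoroacetamide Analogue

This account rests on a few compounds, and the source may have more. Where it says the series, first, only, none or still open, it means among the compounds named here.

Measured compounds:
Compound 1 `O=C1O[C@@H](CN2CCCCC2)CN1c1ccc(-n2cc(-c3ccccn3)cn2)c(F)c1`: 219000 nM
Compound 2 `O=C(NC[C@H]1CN(c2ccc(-n3cc(-c4ccccn4)cn3)c(F)c2)C(=O)O1)C(F)F`: 29900 nM

Two compounds of this series have been examined in a physicochemical assay for solubility, read by HPLC, with a stated time of 24 h; on this read-out lower numbers stand for lower solubility and higher numbers for higher solubility. Compound 1 gives 219000 nM, while compound 2 gives 29900 nM. For the measured compounds named here, compound 2 therefore stands lowest of the two numbers, its nearest neighbour being compound 1; the single step in hand is a 7.3-fold lower number from compound 1 to compound 2 (0.86 log units; beyond the scatter), which arose from putting ((difluoromethyl)carbonyl)amino in place of piperidin-1-yl on a saturated chain carbon bound to a saturated ring carbon.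

Compound 3 `O=C1O[C@@H](CNC(=O)C(F)(F)F)CN1c1ccc(-n2cc(-c3ccccn3)cn2)c(F)c1` has not yet been measured in this assay. It differs from compound 2 only by fluoro in place of hydrogen on a saturated chain carbon bound to a carbonyl carbon and two fluorine atoms. Going by the values given here, no measured step bears directly on a change of this kind: the one step available concerns the exchange of a whole substituent, not a single hydrogen for fluorine, so it gives little guidance on size. On that basis compound 3 is expected to show a small move, if any, in the direction of lower solubility, possibly within the scatter.

Compound 3 is estimated at 20000 nM, with a range of 8000 nM to 45000 nM. For compound 3 this estimate corresponds to a step of a 1.5-fold lower number from compound 2 to compound 3 (0.17 log units; within the scatter).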

Compound 3, solubility: 114000 nM
Estimate against measurement, compound 3: 5.7-fold (0.76 log units) below; the measured number lies above the stated range.
By their numbers in this assay, from the lowest: compound 2; then compounds 3 and 1 (each within the scatter of the next).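

In this assay, for the compounds shown here, the exchange of hydrogen for fluoro on the saturated chain carbon bound to a carbonyl carbon and two fluorine atoms, which turns difluoromethyl into trifluoromethyl, proves to be no silent change: it gives a 3.8-fold higher number from compound 2 to compound 3 (0.58 log units; beyond the scatter), a clear upward move from a single added atom at a position the earlier compounds had not probed. The step from piperidin-1-yl to ((trifluoromethyl)carbonyl)amino gives a 1.9-fold lower number from compound 1 to compound 3 (0.28 log units; within the scatter), whereas the exchange for ((difluoromethyl)carbonyl)amino gave a 7.3-fold lower number from compound 1 to compound 2 (0.86 log units; beyond the scatter), so the drop seen earlier does not carry over to every acylamino group of this kind. Nothing on hand accounts for this difference between the two groups.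

Going by these compounds, what a plain methyl or a monofluoromethyl on the same carbonyl would give remains open, and with it whether the read-out follows the count of fluorine atoms or compound 2 is simply a lone low point. Also open, on these data alone, is how an amide built from a longer chain, or a free primary amine in place of the amide, would read at this position.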